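The compounds below may be only part of what the source reports. "The series", "measured", "known", "first", "only" and "open" are said of these compounds alone.

Of the compounds shown here, two built on one shared core have been tested in an assay on isolated protein for inhibition of MAP kinase-activated protein kinase 5 (Homo sapiens), read by mobility shift assay, tested at 30 uM; a higher number here means more inhibition at the concentration tested (going by the name of the read-out), a lower number less inhibition. Compound 1, `CC(=O)Nc1nn(C)c2cc(-c3ccccc3)[nH]c(=O)c12`, gives 3% in this assay. Compound 2, `Cc1cc2nn(-c3ccccc3)c(N)c2c(=O)[nH]1`, gives 5% in this assay. The two numbers lie within the usual scatter of each other, so neither compound can be set above the other; both sit near the bottom of the scale, meaning that only a small share of the enzyme's activity is blocked at the concentration used.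

The next compound follows from compound 2. Compound 3, `Nc1c2c(=O)[nH]c(-c3ccccc3)cc2nn1-c1ccccc1`, differs from it in one place: phenyl in place of methyl on an aromatic carbon. Within the data shown here, no measured pair shows how a change of this kind moves the read-out, so the numbers give no ground for a step in either direction. Compound 2 gives 5% in this assay. Compound 1 gives 3% in this assay with a different pattern of groups on the same core; both numbers are low. Compound 3 is expected to show a step of a number 1 percentage points higher from compound 2 to compound 3 (within the scatter), which amounts to none beyond the scatter. Compound 3 is therefore estimated at 6%, with a range from -6% to 22%.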

Compound 3, a percentage reported as inhibition, at one concentration (the size of the read-out at that concentration, not a potency): 22%
Estimate against measurement, compound 3: 16 percentage points below, and the stated range covers the measured number.
By their numbers in this assay, from the lowest: compounds 1 and 2 (each within the scatter of the next); then compound 3.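

Phenyl in place of methyl on the aromatic carbon next to the ring nitrogen gives a number 17 percentage points higher from compound 2 to compound 3 (beyond the scatter) in this assay, the first change on this core that can be read in one place. The position is therefore not silent: a group of six carbons carrying an aromatic ring is accepted there, and it goes with more inhibition than methyl, although compound 3, at 22%, still leaves most of the enzyme's activity unblocked at the single concentration tested. Nothing measured here says why the phenyl compound gives the higher number.

A single swap cannot separate the effect of the aromatic ring from that of the larger group, so a cyclohexyl ring, a longer chain such as butyl, or a pyridine ring at this carbon would be needed to tell these apart. Going by these compounds, it also remains open whether substituents on the new phenyl ring, such as a methoxy group or an amine, would raise or lower the inhibition, and whether the same swap gives a similar step when other groups on the shared core are changed.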